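Swapping fluoro for acetamido on the sulfonyl-bound ring

The source may hold more compounds than are shown below. What is called first, only, known or untested is meant among the compounds shown, and "the series" means these compounds.

Measured so far in a functional assay on HepG2 cells (Homo sapiens) for cytotoxicity, read by MTT assay, with a stated time of 24 h; a higher number here means a weaker inhibitor, a lower number a stronger inhibitor:
compound 1 `CC(=O)Nc1ccc(S(=O)(=O)N2C/C(=C\c3ccncc3)C(=O)/C(=C/c3ccccc3F)C2)cc1` gives 11700 nM
compound 2 `O=C1/C(=C/c2ccncc2)CN(S(=O)(=O)c2ccc([N+](=O)[O-])cc2)C/C1=C\c1ccccc1C(F)(F)F` gives 13400 nM
compound 3 `O=C1/C(=C/c2ccncc2)CN(S(=O)(=O)c2ccc(F)cc2)C/C1=C\c1ccccc1C(F)(F)F` gives 4010 nM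

Compound 3 has the lowest number of the three, which marks it as the strongest inhibitor here. Compound 4 `CC(=O)Nc1ccc(S(=O)(=O)N2C/C(=C\c3ccncc3)C(=O)/C(=C/c3ccccc3C(F)(F)F)C2)cc1` differs from it in one place: acetamido in place of fluoro on an aromatic carbon, para to a large group (acetamido in place of fluoro on an aromatic carbon). Among the compounds with values here, the one measured step at this place is a 3.3-fold lower number from compound 2 to compound 3 (0.52 log units; beyond the scatter), with fluoro in place of nitro. The acetamido group already occurs in compound 1 at 11700 nM, though that compound also differs elsewhere. Fluoro leaving should therefore cost some strength, and a modest move to a higher number is expected in this assay, an estimated 2.2-fold higher number from compound 3 to compound 4 (0.35 log units; beyond the scatter). The estimate for compound 4 is 9000 nM, with an expected range of 3500 nM to 22000 nM.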

Compound 4, half-maximal inhibitory concentration: 4840 nM
Compound 4: middle estimate off by 1.9-fold (0.27 log units), on the high side; the measured number falls inside the stated range.
By their numbers in this assay, from the lowest: compounds 3 and 4 (each within the scatter of the next); then compounds 1 and 2 (each within the scatter of the next).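

In this assay the change from 4-fluorophenyl to 4-acetamidophenyl gives a 1.2-fold higher number from compound 3 to compound 4 (0.08 log units; within the scatter) and so stays within the scatter, which shows that this position accepts acetamido as well as fluoro when trifluoromethyl is present elsewhere on the core. Nitro is the group that stands apart at this position, with a 2.8-fold lower number from compound 2 to compound 4 (0.44 log units; beyond the scatter) as the second step showing it. With acetamido held fixed, the other site also counts, giving a 2.4-fold lower number from compound 1 to compound 4 (0.38 log units; beyond the scatter) for trifluoromethyl in place of fluoro.

On these data alone, whether an amine or a carboxylic acid at this position would also match fluoro and acetamido remains open. Nothing available here explains why these steps fall as they do.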